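Acetamido for dimethylamino on the shared core

This account rests on a few compounds, and the source may have more. Where it says the series, first, only, none or still open, it means among the compounds named here.

In an ADME assay on Vero cells (Chlorocebus sabaeus) for cytotoxicity, read by MTT assay, with a stated time of 72 h (a lower number here means that less compound is tolerated, a higher number that more compound is tolerated), compound 1 (`CCOc1ccc(/C=C/C(=O)c2ccc3c(c2O)C=CC(C)(C)O3)cc1`) gives 215000 nM as a measured number. Compound 2 (`CN(C)c1ccc(/C=C/C(=O)c2ccc3c(c2O)C=CC(C)(C)O3)cc1`) is reported only as a limit, > 400000 nM and not as a number. Compound 3 (`CC(=O)Nc1ccc(/C=C/C(=O)c2ccc3c(c2O)C=CC(C)(C)O3)cc1`) carries acetamido in place of dimethylamino on an aromatic carbon, para to a large group (acetamido in place of dimethylamino on an aromatic carbon). Among the measured compounds shown here, only one measured step bears on this place on the ring, (an at least 1.8-fold higher number from compound 1 to compound 2 (0.26 log units; that floor lies within the scatter)), and it gives a floor and no exact size. On that single step, the expected size is an at least 1.3-fold lower number from compound 2 to compound 3 (0.12 log units; that floor lies within the scatter) and no shift beyond the scatter is expected in either direction. In this assay compound 3 is therefore estimated at 300000 nM with an expected range from 130000 nM to 600000 nM for the coming measurement.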

Compound 3, half-maximal cytotoxic concentration: 279000 nM
Compound 3: the middle estimate sits 1.1-fold (0.03 log units) above what was measured, within the range that was stated.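

In this assay the change from ethoxy to acetamido gives a 1.3-fold higher number from compound 1 to compound 3 (0.11 log units; within the scatter), so these two groups cannot be told apart at this place on the ring. The change from dimethylamino to acetamido reads an at least 1.4-fold lower number from compound 2 to compound 3 (0.15 log units; that floor lies within the scatter), and even this floor stays inside the usual scatter, so the step gives a lower bound and no exact size. The value of compound 2 is a limit and not a number: the limit of > 400000 nM in this assay, at which 1 of the 3 values shown sits.

Going by these compounds, it therefore stays open whether dimethylamino truly differs from ethoxy or acetamido here, or whether all three groups read alike. Also open, on these data alone, is how a primary amine, a carboxylic acid or a longer chain on this aromatic carbon of the shared core would read in this assay.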